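A few compounds are considered here, and "the series" means these few. Any claim that something is new, unique, unknown or untested is made for them only; others in the source may bear on it.

Compound 1 `COc1ccccc1-c1cn(C[C@H](O)[C@H]2OC(=O)C(OCc3ccccc3)=C2OCc2ccccc2)nn1` in a functional assay on MCF7 cells (Homo sapiens) for antiproliferative activity, read by MTT assay, with a stated time of 72 h (a lower number here means a stronger inhibitor, a higher number a weaker inhibitor), gives > 100000 nM, which is a limit of the assay and not a number.
Compound 2 `CCCCCCCCCCc1cn(C[C@H](O)[C@H]2OC(=O)C(OCc3ccccc3)=C2OCc2ccccc2)nn1` gives 80 nM.
Compound 3 `CC(C)(C)c1cn(C[C@H](O)[C@H]2OC(=O)C(OCc3ccccc3)=C2OCc2ccccc2)nn1` gives 730 nM.

Of the two measured numbers, compound 3 stands highest, so it is the weaker inhibitor of the two; its nearest neighbour is compound 2, and the gap is a 9.1-fold higher number from compound 2 to compound 3 (0.96 log units; beyond the scatter). Compound 1 sits at the limit of > 100000 nM in this assay, at which 1 of the 3 values shown sits. Compound 4 `O=C1O[C@H]([C@@H](O)Cn2cc(CNS(=O)(=O)c3ccc(Cl)cc3)nn2)C(OCc2ccccc2)=C1OCc1ccccc1` differs from compound 3 in one place: (((4-chlorophenyl)sulfonyl)amino)methyl in place of tert-butyl on an aromatic carbon. Among the compounds with values here, two measured steps concern changes at this same aromatic carbon. Replacing the 2-methoxyphenyl of compound 1 with an alkyl group gave an at least 1200-fold lower number from compound 1 to compound 2 (3.09 log units; beyond the scatter) and an at least 130-fold lower number from compound 1 to compound 3 (2.13 log units; beyond the scatter), both large and toward stronger inhibition, whereas a 9.1-fold higher number from compound 2 to compound 3 (0.96 log units; beyond the scatter) was modest. The group entering compound 4 resembles neither alkyl group: it carries an aromatic ring, as compound 1 does, though held on a sulfonamide-bearing linker rather than attached directly. A step toward a higher number is expected for compound 4, of size an 8.2-fold higher number from compound 3 to compound 4 (0.91 log units; beyond the scatter), because compound 1 with an aromatic ring at this carbon sits at the limit of > 100000 nM in this assay, at which 1 of the 3 values shown sits. There is also a fair chance that only a limit is reported. Compound 4 is estimated at 6000 nM, with a range from 800 nM to 60000 nM.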

Compound 4, half-maximal inhibitory concentration: 4170 nM
Compound 4: the middle estimate sits 1.4-fold (0.16 log units) above what was measured; low and high end bracket the measured number.
By their numbers in this assay, from the lowest: compound 2; then compound 3; then compound 4. At a limit, above all of these: compound 1.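

In this assay, this aromatic carbon of the five-membered ring can carry a group with an aromatic ring and keep measurable activity, as the change from 2-methoxyphenyl to (((4-chlorophenyl)sulfonyl)amino)methyl gives an at least 23-fold lower number from compound 1 to compound 4 (1.37 log units; beyond the scatter). Compound 4 therefore goes against any simple reading that an aromatic ring in this group ends activity, yet this group does not match either alkyl group, with a 5.7-fold higher number from compound 3 to compound 4 (0.76 log units; beyond the scatter), a modest step, and a 52-fold higher number from compound 2 to compound 4 (1.72 log units; beyond the scatter), a large one. Compound 1 remains the only compound here whose result is a limit of the assay and not a number: the limit of > 100000 nM in this assay, at which 1 of the 4 values shown sits.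

The (((4-chlorophenyl)sulfonyl)amino)methyl group differs from the alkyl groups in its linker, its sulfonyl and amino parts, its ring and its chlorine all at once, so these compounds cannot say which of those parts accounts for the number of compound 4. A benzyl group, an amide in place of the sulfonamide, or the same group with hydrogen in place of chlorine would each change fewer of these parts at this carbon.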